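This account rests on a few compounds, and the source may have more. Where it says the series, first, only, none or still open, it means among the compounds named here.

Compound 1 `CCCn1ccc2cc(/C(C)=C/C(=O)Nc3ccccc3OCCCC(=O)O)ccc21` gives 190 nM in an assay on Prostate gland for inhibition of steroid 5-alpha-reductase (Rattus norvegicus); on this read-out lower numbers stand for stronger inhibition and higher numbers for weaker inhibition.
Compound 2 `CCCC(C(C)C)n1ccc2cc(/C(C)=C/C(=O)Nc3ccccc3OCCCC(=O)O)ccc21` gives 7.2 nM in this assay.
Compound 3 `C/C(=C\C(=O)Nc1ccccc1OCCCC(=O)O)c1ccc2c(ccn2Cc2ccc(F)cc2)c1` gives 97 nM in this assay.

Compound 1 stands at the highest number of the three: compound 3 sits nearest, with a 2.0-fold lower number from compound 1 to compound 3 (0.29 log units; within the scatter), and compound 2 furthest, with a 26-fold lower number from compound 1 to compound 2 (1.42 log units; beyond the scatter). Compound 4 `C/C(=C\C(=O)Nc1ccccc1OCCCC(=O)O)c1ccc2c(ccn2Cc2ccc(C(C)(C)C)cc2)c1` has not been measured. It departs from compound 1 in one place: 4-(tert-butyl)phenyl in place of ethyl on a saturated chain carbon bound to an aromatic nitrogen. For the measured compounds named here, two measured steps bear on this. The step to compound 3 puts an aromatic ring on the same saturated chain carbon and stays within the scatter, while the step to compound 2, which enlarges the group on the aromatic nitrogen in a different way, is large. The change to compound 4 adds more than the change to compound 3 did, so a step in this assay somewhat larger than a 2.0-fold lower number from compound 1 to compound 3 (0.29 log units; within the scatter) is expected, toward lower numbers, though smaller than a 26-fold lower number from compound 1 to compound 2 (1.42 log units; beyond the scatter). For compound 4 the expected step is a 4.8-fold lower number from compound 1 to compound 4 (0.68 log units; beyond the scatter), and the estimate is 40 nM, in a range from 8 nM to 200 nM.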

Compound 4, half-maximal inhibitory concentration: 170 nM
For compound 4 the middle estimate is 4.3-fold (0.63 log units) below the measured one; low and high end bracket the measured number.
By their numbers in this assay, from the lowest: compound 2; then compounds 3, 4 and 1 (each within the scatter of the next).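

At the saturated chain carbon bound to the aromatic nitrogen, the much larger 4-(tert-butyl)phenyl group leaves the read-out in this assay essentially unmoved, with a 1.1-fold lower number from compound 1 to compound 4 (0.05 log units; within the scatter), and tert-butyl in place of fluoro on the aromatic carbon also stays inside the scatter, with a 1.8-fold higher number from compound 3 to compound 4 (0.24 log units; within the scatter). Ethyl, 4-fluorophenyl and 4-(tert-butyl)phenyl at this place therefore do not separate compound 1, compound 3 and compound 4, while the 1-isopropylbutyl group on the aromatic nitrogen remains apart, with a 24-fold higher number from compound 2 to compound 4 (1.37 log units; beyond the scatter). Nothing available explains this flat response or the distinct result with 1-isopropylbutyl.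

Going by these compounds, whether a longer unbranched chain such as hexyl on the aromatic nitrogen would match compound 2, or whether that takes a branched group, stays open. So does the outcome with an amine or a hydroxyl in place of tert-butyl on the aromatic carbon.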